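Shifting the amide aryl group: methoxy to chlorine

The source may hold more compounds than are shown below. What is called first, only, known or untested is meant among the compounds shown, and "the series" means these compounds.

Measured so far:
compound 1, `CN(C)C(=O)c1cc2cnc(Nc3ccc(NC(=O)C4(C(=O)Nc5ccc(Cl)c(C(F)(F)F)c5)CC4)cc3)nc2n1C1CCCC1`: 1.1%
compound 2, `COC(=O)c1cccc(NC(=O)C2(C(=O)Nc3ccc(Nc4ncc5cc(C(=O)N(C)C)n(C6CCCC6)c5n4)cc3)CC2)c1`: 10.5%
compound 3, `COc1cccc(NC(=O)C2(C(=O)Nc3ccc(Nc4ncc5cc(C(=O)N(C)C)n(C6CCCC6)c5n4)cc3)CC2)c1`: 77.2%

In a functional assay on A549 cells (Homo sapiens) for inhibition, read by CCK-8 assay, with a stated time of 72 h, tested at 1 uM (a lower number here means less inhibition of growth, a higher number more inhibition of growth at the concentration tested), compound 3 gives the highest of the three numbers. The step of a number 76.1 percentage points higher from compound 1 to compound 3 (beyond the scatter) and the step of a number 66.7 percentage points higher from compound 2 to compound 3 (beyond the scatter) are both large, while a number 9.4 percentage points higher from compound 1 to compound 2 (within the scatter) stays within the scatter. Compound 4, `CN(C)C(=O)c1cc2cnc(Nc3ccc(NC(=O)C4(C(=O)Nc5ccc(Cl)cc5)CC4)cc3)nc2n1C1CCCC1`, is not yet measured; it differs from compound 3 by 4-chlorophenyl in place of 3-methoxyphenyl on an amide-type nitrogen. The nearest guide is compound 1, which also carries chlorine on that ring and gives 1.1%, and compound 2, which also lacks the methoxy group and gives 10.5%. Compound 4 is therefore expected to sit well below compound 3, with the expected step of a number 57.2 percentage points lower from compound 3 to compound 4 (beyond the scatter). The estimate for compound 4 in this assay is 20%, ranging from 2% to 55%.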

Compound 4, percent growth inhibition at one concentration: 24.7%
Compound 4: the middle estimate sits 4.7 percentage points below what was measured; measured number inside the range.
By their numbers in this assay, from the lowest: compounds 1 and 2 (each within the scatter of the next); then compound 4; then compound 3.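

In this assay, swapping 3-methoxyphenyl for 4-chlorophenyl on the amide-type nitrogen gives a number 52.5 percentage points lower from compound 3 to compound 4 (beyond the scatter), so chlorine on this ring does not retain the level reached with methoxy. Removing trifluoromethyl from the chlorinated ring recovers only part of that level, with a number 23.6 percentage points higher from compound 1 to compound 4 (beyond the scatter), and 4-chlorophenyl also compares with 3-(methoxycarbonyl)phenyl at a number 14.2 percentage points higher from compound 2 to compound 4 (beyond the scatter). No evidence here accounts for these differences. The compounds shown leave open whether the higher number depends on methoxy itself or on where it stands, which 4-methoxyphenyl or 3-chlorophenyl would separate. As far as these compounds go, how 3-aminophenyl would read also remains open.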